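The source may hold more compounds than are shown below. What is called first, only, known or untested is meant among the compounds shown, and "the series" means these compounds.

Compound 1, `COc1ccc(OC[C@@H]2CCc3cc([C@H]4CC[C@](N)(CO)C4)ccc3C2)cc1C(C)(C)C`, gives 53% in a functional assay on the whole organism (strain Lewis) with Rattus norvegicus as the target, with a stated time of 24 h, at a dose of 2 mg/kg by the oral route; on this read-out lower numbers stand for less inhibition and higher numbers for more inhibition at the one dose given (going by the name of the read-out).
Compound 2, `COc1ccc(OC[C@@H]2CCc3cc([C@H]4CC[C@](N)(CO)C4)ccc3C2)cc1`, gives 47% in this assay.
Compound 3, `COc1ccc(OC[C@@H]2CCc3cc([C@H]4CC[C@](N)(CO)C4)ccc3C2)c(F)c1F`, gives 48% in this assay.

All three share one core and differ only in the aromatic group attached through an oxygen on a saturated carbon. Going by the values given here, the three numbers sit close together: compound 3 and compound 2 are separated by a number 1 percentage points higher from compound 2 to compound 3 (within the scatter), and the gap from compound 3 to compound 1 is of the same small kind, so no compound can be called stronger or weaker than another here.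

Compound 4, `COc1cccc(OC[C@@H]2CCc3cc([C@H]4CC[C@](N)(CO)C4)ccc3C2)c1`, is not yet measured in this assay. It differs from compound 3 in one place: 3-methoxyphenyl in place of 2,3-difluoro-4-methoxyphenyl on an oxygen on a saturated carbon.

Among the compounds with values here, two measured steps bear on this. The step of a number 1 percentage points higher from compound 2 to compound 3 (within the scatter) changed the same aromatic group at the same oxygen. The step of a number 6 percentage points lower from compound 1 to compound 2 (within the scatter) removed a tert-butyl from an aromatic carbon. Both stayed within the scatter, so exchanging one methoxyphenyl variant for another is expected to leave the number about where it is, with no step beyond the scatter in either direction.

For compound 4 the expected step is no change at the digits printed from compound 3 to compound 4 (within the scatter). Compound 4 is therefore estimated at 48% in this assay, with a range from 35% to 60%.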

Compound 4, a percentage reported as inhibition, in the whole organism at one dose (the size of the read-out at that dose, not a potency): 86%
Estimate against measurement, compound 4: 38 percentage points below, outside the stated range (above it).
By their numbers in this assay, from the lowest: compounds 2, 3 and 1 (each within the scatter of the next); then compound 4.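

Two changes at this position show that the aromatic group on the oxygen matters far more in this assay than the first three compounds suggested: putting 3-methoxyphenyl in place of 2,3-difluoro-4-methoxyphenyl gives a number 38 percentage points higher from compound 3 to compound 4 (beyond the scatter), and putting it in place of 4-methoxyphenyl gives a number 39 percentage points higher from compound 2 to compound 4 (beyond the scatter). The second change is the more telling, since the two group names differ only in the number that places the methoxy group, and both groups have the same heavy-atom count, so moving that one group is enough to produce a large step at this single dose. The data shown offer no measurement that accounts for this large step.

The compounds shown leave open whether the gain depends on the methoxy group itself or would also appear with another group in the same numbered place, such as 3-aminophenyl, 3-cyanophenyl or 3-ethoxyphenyl. They also leave open how 2-methoxyphenyl would behave, and whether adding fluorine to the 3-methoxyphenyl group would keep the high number, since a read-out at one dose gives the size of the effect and not a potency.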